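A few compounds are considered here, and "the series" means these few. Any claim that something is new, unique, unknown or untested is made for them only; others in the source may bear on it.

Compound 3 `C=C1C(=O)N(c2ccccc2)N(c2ccccc2)C1CC` gives 20000 nM in a functional assay on MCF7 cells (Homo sapiens) for inhibition, read by MTT assay, with a stated time of 48 h; a higher number here means a weaker inhibitor, a lower number a stronger inhibitor. Among the three measured compounds it stands second highest: compound 1 `C=C1C(=O)N(c2ccccc2)N(c2ccccc2)C1c1ccccc1` gives 4500 nM in this assay, and compound 2 `C=C1CN(C)N(c2ccc(C)cc2)C1=O` gives 59100 nM. Compound 4 `C=C1C(=O)N(c2ccccc2)N(c2ccccc2)C1C` differs from compound 3 by hydrogen in place of methyl on a saturated chain carbon bound to a saturated ring carbon, which read one bond further out is ethyl to methyl. For the measured compounds named here, the only measured step that bears on it is a 4.4-fold higher number from compound 1 to compound 3 (0.65 log units; beyond the scatter), where ethyl in place of phenyl on the saturated ring carbon gave a weaker inhibitor; compound 2 has a different core and offers no step. Taking one more carbon away is expected to change little, so the step of a 1.3-fold higher number from compound 3 to compound 4 (0.10 log units; within the scatter) is estimated to be within the scatter or a small weakening. Compound 4 is therefore expected to give 25000 nM, with a range from 9000 nM to 70000 nM.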

Compound 4, half-maximal inhibitory concentration: 12500 nM
Beside the measured number, compound 4's estimate is 2.0-fold (0.30 log units) above it; the measured number falls inside the stated range.
By their numbers in this assay, from the lowest: compound 1; then compounds 4 and 3 (each within the scatter of the next); then compound 2.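

Shortening ethyl to methyl at this position leaves the reading within the scatter, with a 1.6-fold lower number from compound 3 to compound 4 (0.20 log units; within the scatter) in this assay, so these two small alkyl groups cannot be told apart. Methyl in place of phenyl on a saturated ring carbon gives a 2.8-fold higher number from compound 1 to compound 4 (0.44 log units; beyond the scatter) and so a weaker inhibitor, which places phenyl apart from both alkyl groups. No measurement shown here offers a reason for these readings.

From the compounds shown here alone, what stays open is how a longer chain, a benzyl group or an amine at this position would read. Going by these compounds, it also stays open whether a phenyl bearing a methoxy group or a chlorine would keep the reading of the unsubstituted phenyl.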